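A few compounds are considered here, and "the series" means these few. Any claim that something is new, unique, unknown or untested is made for them only; others in the source may bear on it.

Compound 3 `Fc1ccccc1/C=N/c1sc2c(c1-c1nc3ccccc3s1)CCCC2` stands at the top of the three numbers recorded in an ADME assay on HepG2 cells (Homo sapiens) for cytotoxicity, read by MTT assay, with a stated time of 72 h (on this read-out higher numbers stand for lower toxicity in this test and lower numbers for higher toxicity in this test), where compound 3 gives 398 ug/mL. Compound 2 `Clc1ccc(/C=N/c2sc3c(c2-c2nc4ccccc4s2)CCC3)c(Cl)c1` gives 310 ug/mL, a figure within the scatter of that of compound 3, while compound 1 `Clc1ccccc1/C=N/c1sc2c(c1-c1nc3ccccc3s1)CCC2` gives 180 ug/mL, a figure lying beyond the scatter below compound 3. Among the measured compounds shown here, the one single-point step among the measured compounds, a 1.7-fold higher number from compound 1 to compound 2 (0.24 log units; within the scatter), shows that chloro in place of hydrogen on an aromatic carbon left the number essentially where it was. Compound 4 `Oc1ccccc1/C=N/c1sc2c(c1-c1nc3ccccc3s1)CCCC2` differs from compound 3 by hydroxy in place of fluoro on an aromatic carbon. For the measured compounds named here, no measured step exchanges a fluoro for a hydroxy, so the recorded step bears on it only as a general indication that a single small change on this ring has so far moved the number little. Compound 4 is therefore expected to land close to compound 3. The step of a 1.1-fold lower number from compound 3 to compound 4 (0.06 log units; within the scatter) that this estimate implies is expected to stay within the scatter. Compound 4 is estimated at 350 ug/mL, with a range from 150 ug/mL to 700 ug/mL.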

Compound 4, half-maximal cytotoxic concentration: 114 ug/mL
Estimate against measurement, compound 4: 3.1-fold (0.49 log units) above, outside the stated range (below it).
By their numbers in this assay, from the lowest: compounds 4, 1, 2 and 3 (each within the scatter of the next, the first and the last beyond it).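

In this assay the exchange of 2-fluorophenyl for 2-hydroxyphenyl gives a 3.5-fold lower number from compound 3 to compound 4 (0.54 log units; beyond the scatter) and so moves the number towards higher toxicity in this test. Among the compounds shown here, this shows that a change of one group at this place, on the six-membered aromatic ring of carbon only and ortho to a large group, can carry the number beyond the scatter, which the chloro step among the earlier compounds did not show. Nothing measured here gives a reason for this step.

The compounds shown leave open whether the fall belongs to the hydroxy itself, since an amine or a methoxy at this same place would be needed to tell. They also leave open whether hydroxy in place of fluoro would act alike on the core of compound 1.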